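From a Nitro Group to an Ester: an Expected Step

The compounds below may be only part of what the source reports. "The series", "measured", "known", "first", "only" and "open" are said of these compounds alone.

Of the compounds shown here, three have so far been tested in a functional assay on COLO 320 cells (Homo sapiens) for cytotoxicity, read by WST assay, with a stated time of 72 h; a higher number here means a weaker inhibitor, a lower number a stronger inhibitor. Compound 1 `COc1cccc(-c2cc(-c3cc4cc(OC)ccc4[nH]3)no2)c1` reaches only a limit of this assay, > 100000 nM. Compound 3 `COc1ccc(-c2cc(-c3cc4ccccc4n3C)on2)cc1` likewise gives only a limit, > 100000 nM. For the measured compounds named here, compound 2 `O=[N+]([O-])c1ccc(-c2cc(-c3ccc4[nH]ccc4c3)on2)cc1` is the single member with a measured number: in this assay compound 2 gives 14000 nM, so it stands alone as the one compound whose inhibition could be put into a number, while the other two sit at the limit of > 100000 nM in this assay, at which 2 of the 3 values shown sit.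

Compound 4 `COC(=O)c1ccc(-c2cc(-c3ccc4[nH]ccc4c3)on2)cc1` has not yet been tested. It differs from compound 2 in one place (methoxycarbonyl in place of nitro on an aromatic carbon), methoxycarbonyl in place of nitro on an aromatic carbon. Going by the values given here, no measured pair among the three compounds shows this swap, so its size cannot be read from the data. A small step is expected, with a slight lean towards a weaker inhibitor, but not beyond the usual scatter. Compound 4 is therefore expected to give about 20000 nM in this assay, with a range from 6000 nM to 70000 nM. This estimate means a step of a 1.4-fold higher number from compound 2 to compound 4 (0.15 log units; within the scatter) that is expected to stay within the usual scatter.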

Compound 4, half-maximal inhibitory concentration: > 100000 nM
Compound 4 was reported as a limit (the forecaster's own chance of this, stated with the estimate: 15%); at least 5.0-fold (0.69 log units) between middle value and limit.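

At this place on the aromatic ring, para to a large group, putting methoxycarbonyl in place of nitro gives an at least 7.1-fold higher number from compound 2 to compound 4 (0.85 log units; beyond the scatter) in this assay. For the compounds shown here, this is the first pair differing in one place, so the size of a single change can now be read, and it goes beyond the scatter even though both groups count the same hydrogen-bond donors and acceptors. The value of compound 4 is a limit and not a number, which leaves compound 2 as the only compound with a measured number: the limit of > 100000 nM in this assay, at which 3 of the 4 values shown sit.

From the compounds shown here alone, how an amine or a carboxylic acid at this place would compare with nitro stays open. Also open, going by these compounds, is whether the same swap would give a similar step on the core of compound 1 or compound 3.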